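Moving the boronic acid around the ring in a second core

This account rests on a few compounds, and the source may have more. Where it says the series, first, only, none or still open, it means among the compounds named here.

Measured so far:
compound 1, `CC(C)CN(NC(=O)OCc1ccccc1)C(=O)CN(Cc1ccccc1)/N=C/c1ccccc1B(O)O`, 45100 nM
compound 2, `CC(C)CN(CC(=O)N(Cc1ccccc1)NC(=O)OCc1ccccc1)/N=C/c1ccccc1B(O)O`, 25100 nM
compound 3, `CC(C)CN(NC(=O)OCc1ccccc1)C(=O)CN(Cc1ccccc1)/N=C/c1cccc(B(O)O)c1`, 18400 nM

Of the compounds shown here, three have been tested in a functional assay on B16 cells (Mus musculus) for inhibition; on this read-out lower numbers stand for stronger inhibition and higher numbers for weaker inhibition. Compound 1 and compound 3 share a core and differ in one place: a group of 9 heavy atoms (6 carbon, 1 boron, 2 oxygen; one six-membered aromatic ring of carbon only) in place of a group of 9 heavy atoms (6 carbon, 1 boron, 2 oxygen; one six-membered aromatic ring of carbon only), on a carbon with a double bond to nitrogen. That change gave a 2.5-fold lower number from compound 1 to compound 3 (0.39 log units; beyond the scatter).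

Compound 2 is built on a different core. How its core differs from that of compound 1 is not broken down here. In this assay compound 2 gives 25100 nM, and its values against compound 1 and compound 3 fall within the scatter of repeated measurements, so no order among them can be read.

Compound 4, `CC(C)CN(CC(=O)N(Cc1ccccc1)NC(=O)OCc1ccccc1)/N=C/c1cccc(B(O)O)c1`, has not yet been measured. It stands to compound 2 as compound 3 stands to compound 1: a group of 9 heavy atoms (6 carbon, 1 boron, 2 oxygen; one six-membered aromatic ring of carbon only) in place of a group of 9 heavy atoms (6 carbon, 1 boron, 2 oxygen; one six-membered aromatic ring of carbon only), on a carbon with a double bond to nitrogen. The place of the change is the same in both pairs, so the change is the same one, carried over to the second core.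

If the change behaves on the core of compound 2 as it did on the core of compound 1, the number for compound 4 is expected to fall by about as much; the estimated step is a 2.1-fold lower number from compound 2 to compound 4 (0.32 log units; beyond the scatter), resting on a 2.5-fold lower number from compound 1 to compound 3 (0.39 log units; beyond the scatter). This rests on a single earlier example, so the expected range is kept wide. Compound 4 is therefore estimated at 12000 nM, with a range from 5000 nM to 30000 nM.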

Compound 4, half-maximal inhibitory concentration: 19900 nM
Compound 4: the middle estimate sits 1.7-fold (0.22 log units) below what was measured; low and high end bracket the measured number.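

In this assay, the same change on the second core gives a 1.3-fold lower number from compound 2 to compound 4 (0.10 log units; within the scatter), so on this core alone its effect cannot be told apart from the ordinary spread of repeated measurements. The step on the second core also cannot be told apart from the step on the first, so nothing here shows that the core alters what the change does: the same change on two cores in this assay, a 2.5-fold lower number (0.39 log units; beyond the scatter) from compound 1 to compound 3 and a 1.3-fold lower number (0.10 log units; within the scatter) from compound 2 to compound 4, 1.9-fold (0.29 log units) apart, within the scatter of two such steps. Within the data shown here, that agreement does not prove that the change carries over, since one pair on each core cannot separate a real step of similar size, hidden in the scatter, from no step at all on the second core, and two cores say nothing about any further core.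

On these data alone, it remains open whether the boronic acid is needed at all, and whether either core would respond more clearly to a different group, such as a carboxylic acid or an amine, in its place. As far as these compounds go, it is also open whether a longer chain in place of the isobutyl group would shift the numbers on either core by more than the scatter.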